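A few compounds are considered here, and "the series" means these few. Any claim that something is new, unique, unknown or untested is made for them only; others in the source may bear on it.

The measured compounds:
compound 1, `CCCc1cnc(N2CCC(C3Cc4cc(C5=CCN(S(=O)(=O)CCCO)CC5)cc(F)c4O3)CC2)nc1`, 100%
compound 2, `CCCc1cnc(N2CCC(C3Cc4cc(C5=CCN(S(=O)(=O)CCCCO)CC5)cc(F)c4O3)CC2)nc1`, 73%
compound 3, `CCCc1cnc(N2CCC(C3(C)Cc4cc(C5=CCN(S(=O)(=O)CCCO)CC5)ccc4O3)CC2)nc1`, 72%

All three were tested in an ADME assay (liver) for metabolic stability, with Liver microsome (Homo sapiens) as the target, using microsomes, with a stated time of 10 min; on this read-out higher numbers stand for a more stable compound and lower numbers for a less stable compound. Compound 1 and compound 2 differ in one place only: hydroxymethyl in place of hydroxy on a saturated chain carbon, three bonds along the chain from a sulfonyl sulfur. That change gave a number 27 percentage points lower from compound 1 to compound 2 (beyond the scatter). Compound 3 stands on a different core; the difference between the core of compound 1 and the core of compound 3 is not broken down here. In this assay compound 3 and compound 2 lie within the scatter of each other, while compound 3 sits well apart from compound 1.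

Compound 4, `CCCc1cnc(N2CCC(C3(C)Cc4cc(C5=CCN(S(=O)(=O)CCCCO)CC5)ccc4O3)CC2)nc1`, has not yet been measured in this assay. It differs from compound 3 by hydroxymethyl in place of hydroxy on a saturated chain carbon, three bonds along the chain from a sulfonyl sulfur, the same change as that between compound 1 and compound 2, at a place described in identical words. For the measured compounds named here, the step is expected to be a number 24 percentage points lower from compound 3 to compound 4 (beyond the scatter) because a number 27 percentage points lower from compound 1 to compound 2 (beyond the scatter) is the only measured instance of this change, and compound 3 starts lower than compound 1 did. Compound 4 is therefore expected to give 48%, with a range from 28% to 68%.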

Compound 4, percent of the compound remaining: 67%
For compound 4 the middle estimate is 19 percentage points below the measured one, and the stated range covers the measured number.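

On the core of compound 3, the change from hydroxy to hydroxymethyl at this place on the chain gave a number 5 percentage points lower from compound 3 to compound 4 (within the scatter) in this assay. The step therefore did not carry over from one core to the other as a fixed amount, and the size measured on the core of compound 1 would have misjudged the step on the core of compound 3: the same change on two cores in this assay, a number 27 percentage points lower (beyond the scatter) from compound 1 to compound 2 and a number 5 percentage points lower (within the scatter) from compound 3 to compound 4, 22 percentage points apart, beyond the scatter of two such steps This does not show which difference between the two cores goes with the gap, and two pairs set no rule for how the change behaves on other cores in this series.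

The compounds shown leave open how a chain longer than 4-hydroxybutyl would read in this assay, and whether an amine or a carboxylic acid in place of the hydroxy would follow the same course. They also leave open how the same step would read on a third core, one that differs from the core of compound 1 in a single place.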